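A Larger Aromatic Group on the Shared Core

This account rests on a few compounds, and the source may have more. Where it says the series, first, only, none or still open, it means among the compounds named here.

For the measured compounds named here, compound 2 `Cc1cc(C#N)cc(C)c1Oc1nc(Nc2ccc(C#N)cc2)ncc1-c1cccs1` gives 6430 nM in an ADME assay on MT4 cells (Homo sapiens) for cytotoxicity, read by MTT assay, with a stated time of 5 days (on this read-out lower numbers stand for higher toxicity in this test and higher numbers for lower toxicity in this test), the lowest of the two numbers measured so far; compound 1 `Cc1cc(C#N)cc(C)c1Oc1nc(Nc2ccc(C#N)cc2)ncc1-c1ccccc1` gives 31800 nM. Going by the values given here, the only measured step, a 4.9-fold lower number from compound 1 to compound 2 (0.69 log units; beyond the scatter), exchanged phenyl for thiophen-2-yl at the same position. Among the compounds with values here, compound 3 `Cc1cc(C#N)cc(C)c1Oc1nc(Nc2ccc(C#N)cc2)ncc1-c1ccc2ccccc2c1` carries naphthalen-2-yl in place of thiophen-2-yl on an aromatic carbon, and no measured step covers this particular exchange. Because compound 2 already stands at the lower end after a 4.9-fold lower number from compound 1 to compound 2 (0.69 log units; beyond the scatter), the account expects only a modest further step, a 1.6-fold lower number from compound 2 to compound 3 (0.21 log units; within the scatter), toward a lower number. Compound 3 is therefore estimated at 4000 nM, within a range from 1000 nM to 20000 nM.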

Compound 3, half-maximal cytotoxic concentration: 8460 nM
The estimate for compound 3 lay 2.1-fold (0.33 log units) below the measured number, within the range that was stated.
By their numbers in this assay, from the lowest: compounds 2 and 3 (each within the scatter of the next); then compound 1.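

In this assay, the larger naphthalen-2-yl and the thiophen-2-yl give numbers within the scatter of each other (a 1.3-fold higher number from compound 2 to compound 3 (0.12 log units; within the scatter)), even though one carries two six-membered aromatic rings of carbon only and the other a five-membered aromatic ring with a sulfur. Against phenyl, naphthalen-2-yl also gives a step beyond the scatter (a 3.8-fold lower number from compound 1 to compound 3 (0.58 log units; beyond the scatter)), so among these three compounds the lower number is not confined to thiophen-2-yl. No evidence at hand accounts for this.

On these data alone, what an amine or a carboxylic acid at this position would give remains open.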